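Swapping methylsulfanyl for tetrazole on an amide series

A few compounds are considered here, and "the series" means these few. Any claim that something is new, unique, unknown or untested is made for them only; others in the source may bear on it.

Of the compounds shown here, three sharing an amide core have been tested in an assay on HeLa cells with Bile acid receptor (Homo sapiens) as the target, read by a luciferase reporter, with a stated time of 24 h; on this read-out higher numbers stand for an effect only at larger amounts of compound and lower numbers for an effect already at smaller amounts. Compound 1, `CSc1ccc(CNC(=O)c2ccc(C(C)(C)C)cc2)cc1`, gives 100 nM in this assay. Compound 2, `CC(C)(C)c1ccc(C(=O)NCc2ccc(C(=O)O)c(Cl)c2)cc1`, gives 8.8 nM, and compound 3, `Cc1ccc(C(=O)NCc2ccc(C(=O)O)cc2)cc1C`, gives 320 nM. Among the three numbers, compound 1 stands second highest: its nearest neighbour is compound 3, whose number is higher by a margin beyond the usual scatter, while compound 2 sits furthest away with a much lower number, also well beyond the scatter.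

Compound 4, `CC(C)(C)c1ccc(C(=O)NCc2ccc(-c3nnn[nH]3)cc2)cc1`, has not yet been measured. It differs from compound 1 in one place: 1H-tetrazol-5-yl in place of methylsulfanyl on an aromatic carbon. The group that leaves is small and uncharged; the group that enters brings a five-membered aromatic ring with four hetero atoms and adds a hydrogen-bond donor.

Among the compounds with values here, no pair of measured compounds differs in exactly this way, so the size of the step cannot be read from a measured pair. Still, a step toward a lower number is expected, since compound 2 reaches 8.8 nM while carrying a hydrogen-bond donor on the same ring. Compound 4 is therefore estimated at 25 nM, with a plausible range from 6 nM to 100 nM, which corresponds to an expected step of a 4.0-fold lower number from compound 1 to compound 4 (0.60 log units; beyond the scatter).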

Compound 4, half-maximal effective concentration: 120 nM
The estimate for compound 4 lay 4.8-fold (0.68 log units) below the measured number; measured number above the stated range.
By their numbers in this assay, from the lowest: compound 2; then compounds 1 and 4 (each within the scatter of the next); then compound 3.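

In this assay, putting 1H-tetrazol-5-yl in place of methylsulfanyl on an aromatic carbon para to a large group gives a 1.2-fold higher number from compound 1 to compound 4 (0.08 log units; within the scatter), so this single exchange leaves the two compounds indistinguishable on this read-out. Within the data shown here, this pair is the first direct test of this place, and it shows that a small group with no ring can give way to a five-membered aromatic ring with four hetero atoms and a hydrogen-bond donor without the number moving beyond the usual scatter; in this pair, then, gaining a hydrogen-bond donor at this place does not by itself bring a lower number. No measurement available here explains why the two groups read alike.

Compound 2 differs from compound 4 in more than one place, so these compounds cannot show which of its features goes with its low number. On these data alone, how other groups would read at this same place, such as an amine, a nitrile or a methoxy group, also remains open.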